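The source may report more compounds than this note shows. Statements on the series, on what has been measured and on what is new or still open speak of the compounds shown alone.

Measured compounds: compound 1 `CC(C)(CNC(=O)c1ccc2ccccc2c1O)CC1=C(O)C(=O)c2ccccc2C1=O` gives 93700 nM; compound 2 `COC1=C(CC(C)(C)CNC(=O)c2ccccc2)C(=O)c2ccccc2C1=O` gives 12300 nM.

Both numbers come from an ADME assay on Vero cells (Chlorocebus sabaeus) for cytotoxicity, read by fluorescence, with a stated time of 4 days; a lower number here means a stronger inhibitor, a higher number a weaker inhibitor. Of the two measured compounds, compound 1 stands with the highest number, and its nearest neighbour, compound 2, sits at a lower number that lies beyond the usual scatter. Among the compounds with values here, no step between these two is counted here, so only their two values speak.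

Compound 3 `COc1c(C(=O)NCC(C)(C)CC2=C(O)C(=O)c3ccccc3C2=O)ccc2ccccc12` has not yet been measured in this assay. It differs from compound 1 by methyl in place of hydrogen on an oxygen on an aromatic ring. Within the data shown here, no measured pair shows this change, so the size of the step is uncertain. A small move toward a lower number is expected for compound 3, a 1.6-fold lower number from compound 1 to compound 3 (0.19 log units; within the scatter), though it may stay within the scatter of compound 1. Compound 3 is estimated at 60000 nM, with a range from 20000 nM to 150000 nM.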

Compound 3, half-maximal inhibitory concentration: 47300 nM
For compound 3 the middle estimate is 1.3-fold (0.10 log units) above the measured one, and the stated range covers the measured number.
By their numbers in this assay, from the lowest: compound 2; then compounds 3 and 1 (each within the scatter of the next).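

In this assay, methyl in place of hydrogen on an oxygen on an aromatic ring gives a 2.0-fold lower number from compound 1 to compound 3 (0.30 log units; within the scatter), a step that lies within the scatter. Within the data shown here, this is the first reading of the hydroxy to methoxy change at this position, and on the core of compound 1 it does not separate the two compounds, so the hydrogen on this oxygen can be replaced by methyl without a change that can be told from the scatter in this read-out. No measured evidence that bears on this result is at hand.

From the compounds shown here alone, whether a longer chain on this oxygen, such as ethyl, or an amine in place of the methoxy would move the number beyond the scatter remains open. Going by these compounds, with a single pair, it also remains open whether the same change would give a similar step on another core.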